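The source may report more compounds than this note shows. Statements on the series, on what has been measured and on what is new or still open speak of the compounds shown alone.

Going by the values given here, in a functional assay on NIH3T3 cells (Mus musculus) (a higher number here means that more compound is needed for the effect, a lower number that less compound is needed), compound 3 `Cn1cncc1C(OCc1ccc(C#N)cc1/C=C/c1ccc([N+](=O)[O-])cc1)c1ccc(C#N)cc1` gives 2.24 nM and holds the lowest number so far, with compound 2 `Cn1cncc1C(OCc1ccc(C#N)cc1/C=C/c1ccccn1)c1ccc(C#N)cc1` at 23.1 nM and compound 1 `Cn1cncc1C(OCc1ccc(C#N)cc1-c1ccccc1)c1ccc(C#N)cc1` at 140 nM higher up. Compound 4 `Cn1cncc1C(OCc1ccc(C#N)cc1CCC(C)(C)C)c1ccc(C#N)cc1` brings 3,3-dimethylbutyl in place of 2-(4-nitrophenyl)ethenyl on an aromatic carbon in this series. Among the compounds with values here, three measured steps bear on this change: a 6.1-fold lower number from compound 1 to compound 2 (0.78 log units; beyond the scatter) is modest, while a 63-fold lower number from compound 1 to compound 3 (1.80 log units; beyond the scatter) and a 10-fold lower number from compound 2 to compound 3 (1.01 log units; beyond the scatter) are both large. Within the data shown here, these show how far the number moves with the group at this place, but no measured compound carries a chain without a ring there. The expectation is a large step to a higher number in this assay with an estimated 27-fold higher number from compound 3 to compound 4 (1.43 log units; beyond the scatter) as the working figure. Compound 4 is estimated at 60 nM with an expected range from 10 nM to 350 nM in this assay.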

Compound 4, half-maximal effective concentration: 0.54 nM
The estimate for compound 4 lay 110-fold (2.05 log units) above the measured number; measured number outside the range, below it.
By their numbers in this assay, from the lowest: compound 4; then compound 3; then compound 2; then compound 1.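

At the aromatic carbon ortho to a large group, a ring is not required for a low number in this assay: 3,3-dimethylbutyl, which has no ring, gives a 4.1-fold lower number from compound 3 to compound 4 (0.62 log units; beyond the scatter), along with a 43-fold lower number from compound 2 to compound 4 (1.63 log units; beyond the scatter) and a 260-fold lower number from compound 1 to compound 4 (2.41 log units; beyond the scatter). All three steps lie beyond the scatter, so the only chain without a ring holds the lowest number of the four compounds. Nothing measured here explains this result.

Going by these compounds, whether the branched end of the chain matters remains open. A straight hexyl chain, or a shorter chain ending in an amine, would test this.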